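Replacing an Amide with a Dimethylamino Group

A few compounds are considered here, and "the series" means these few. Any claim that something is new, unique, unknown or untested is made for them only; others in the source may bear on it.

Measured in a functional assay on HCT-116 cells (Homo sapiens) for inhibition; on this read-out lower numbers stand for stronger inhibition and higher numbers for weaker inhibition:
compound 1 `CCNC(=O)c1noc(-c2cc(C(C)C)c(O)cc2O)c1-c1cc(COCC(=O)OC)no1` gives 262 nM
compound 2 `CCNC(=O)c1noc(-c2cc(C(C)C)c(O)cc2O)c1-c1cc(CNC)no1` gives 164 nM
compound 3 `CCNC(=O)c1noc(-c2cc(C(C)C)c(O)cc2O)c1-c1cc(CNC(=O)CC)no1` gives 78 nM

Compound 3 has the lowest number of the three, and its steps to both others lie beyond the scatter. Compound 4 `CCNC(=O)c1noc(-c2cc(C(C)C)c(O)cc2O)c1-c1cc(CN(C)C)no1` keeps the shared core but carries dimethylamino in place of propanoylamino on a saturated chain carbon bound to an aromatic carbon. The closest guide is the modest step of a 2.1-fold lower number from compound 2 to compound 3 (0.32 log units; beyond the scatter) where propanoyl replaced methyl on an amine nitrogen. Compound 4 reverses that kind of change, since its nitrogen again carries methyl and no propanoyl, so its nearest measured relative is compound 2 (164 nM). The modest step of a 3.4-fold lower number from compound 1 to compound 3 (0.53 log units; beyond the scatter) also favours the propanoylamino group, while the step of a 1.6-fold lower number from compound 1 to compound 2 (0.20 log units; within the scatter) stays within the scatter. Going by the values given here, no measured compound shows what a second methyl does. In this assay the expected change is a 2.1-fold higher number from compound 3 to compound 4 (0.31 log units; beyond the scatter) and so a modest move toward weaker inhibition. For compound 4 the estimated value is 160 nM (expected range 70 nM to 370 nM).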

Compound 4, half-maximal inhibitory concentration: 92 nM
Estimate against measurement, compound 4: 1.7-fold (0.24 log units) above, within the range that was stated.
By their numbers in this assay, from the lowest: compounds 3, 4, 2 and 1 (each within the scatter of the next, the first and the last beyond it).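

In this assay, the change from (propanoylamino)methyl to (dimethylamino)methyl gives a 1.2-fold higher number from compound 3 to compound 4 (0.07 log units; within the scatter), so at this place on a saturated chain carbon bound to an aromatic carbon, a group with 0 hydrogen-bond donors cannot be told apart from one with 1. Adding a second methyl to the amine nitrogen gives a 1.8-fold lower number from compound 2 to compound 4 (0.25 log units; within the scatter), so this small change also cannot be separated from assay scatter. Replacing (methoxycarbonyl)methoxy with dimethylamino gives a 2.8-fold lower number from compound 1 to compound 4 (0.45 log units; beyond the scatter), a modest gain that the single methyl of the methylamino group does not clearly show.

The data shown offer no measurement that explains why these groups compare as they do. Still open, going by these compounds, is how a larger amine such as diethylamino, or a ring amine such as morpholine, would compare at this place.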